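Chain Lengthening on the Methyl Ester Core

The source may hold more compounds than are shown below. What is called first, only, known or untested is meant among the compounds shown, and "the series" means these compounds.

Compound 2 `C=C(C)C(=O)c1ccc(OC(C)C(=O)OC)c(C)c1C` is measured in a functional assay on HL-60 cells (Homo sapiens) for antiproliferative activity, with a stated time of 72 h (a lower number here means a stronger inhibitor of growth, a higher number a weaker inhibitor of growth), where compound 2 gives 6000 nM. Two acids carry a different core: compound 1 `C=C(CCCC)C(=O)c1ccc(OCC(=O)O)c(C)c1C` gives 14400 nM in this assay, and compound 3 `C=C(CCC)C(=O)c1ccc(OCC(=O)O)c(C)c1C` gives 19300 nM. The difference between the core of compound 2 and the core of compound 3 is not broken down here; compound 2 stands lowest of the three, with compound 1 nearest and compound 3 furthest. Between compound 3 and compound 1 the change is methyl in place of hydrogen on a saturated chain carbon, three bonds along the chain from a double-bonded chain carbon, and it made a 1.3-fold lower number from compound 3 to compound 1 (0.13 log units; within the scatter). Compound 4 `C=C(CC)C(=O)c1ccc(OC(C)C(=O)OC)c(C)c1C` is not yet measured. It differs from compound 2 by methyl in place of hydrogen on a saturated chain carbon bound to a double-bonded chain carbon, the same kind of change, but here the entering methyl sits on a saturated chain carbon bound to a double-bonded chain carbon, not three bonds along the chain from one. Because a 1.3-fold lower number from compound 3 to compound 1 (0.13 log units; within the scatter) stayed within the scatter, compound 4 is expected to move by a 1.2-fold lower number from compound 2 to compound 4 (0.08 log units; within the scatter) in this assay. The estimate for compound 4 is 5000 nM, between 2500 nM and 12000 nM.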

Compound 4, concentration for 50% growth inhibition: 4600 nM
Beside the measured number, compound 4's estimate is 1.1-fold (0.04 log units) above it; low and high end bracket the measured number.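

In this assay, methyl in place of hydrogen on a saturated chain carbon bound to a double-bonded chain carbon gives a 1.3-fold lower number from compound 2 to compound 4 (0.12 log units; within the scatter). Set beside the earlier step on the core of compound 3, the new step agrees with it within the scatter: the same change on two cores in this assay, a 1.3-fold lower number (0.13 log units; within the scatter) from compound 3 to compound 1 and a 1.3-fold lower number (0.12 log units; within the scatter) from compound 2 to compound 4, 1.0-fold (0.01 log units) apart, within the scatter of two such steps

Going by these compounds alone, in this series, then, the change carries from one core to the other without a step beyond the scatter on either, but this rests on only two pairs, with the methyl entering at a different place on the chain in each, and neither step shows a real gain in growth inhibition that travels between cores. The compounds shown leave open whether a phenyl ring or an amine in place of the entering methyl would give a step beyond the scatter on either core. As far as these compounds go, whether the carboxylic acid and the methyl ester differ on an otherwise shared core also stays open.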